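This account rests on a few compounds, and the source may have more. Where it says the series, first, only, none or still open, it means among the compounds named here.

Of the compounds shown here, two of the same core have been tested so far in a functional assay on the whole organism (strain Swiss albino) for inhibition, with Mus musculus as the target, in the maximal electroshock model, with a stated time of 2 h, at a dose of 25 mg/kg by the intraperitoneal route; on this read-out lower numbers stand for less inhibition and higher numbers for more inhibition at the one dose given (going by the name of the read-out). Compound 1 `CN1C(=O)C(c2ccccc2)CC(c2ccccc2)C1=O` carries a methyl on the amide-type nitrogen in the ring, and in this assay compound 1 gives 69.1%. Compound 2 `O=C1C(c2ccccc2)CC(c2ccccc2)C(=O)N1c1cccc(Cl)c1` carries a 3-chlorophenyl at that nitrogen instead, and in this assay compound 2 gives 32.2%. Among the measured compounds shown here, the one measured step, a number 36.9 percentage points lower from compound 1 to compound 2 (beyond the scatter), shows that exchanging the methyl for the 3-chlorophenyl went along with a large loss. Compound 2 thus stands at the lower of the two numbers.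

Compound 3 `Cc1ccccc1N1C(=O)C(c2ccccc2)CC(c2ccccc2)C1=O` is the next compound. It differs from compound 2 as follows: 2-methylphenyl in place of 3-chlorophenyl on an amide-type nitrogen in a ring.

For the measured compounds named here, no measured step covers a change from one aromatic ring to another at this nitrogen; the only step known concerns the move from methyl to an aromatic ring. Since compound 3 keeps an aromatic ring at that position, it is expected to stay near the level of compound 2, with a step of a number 2.8 percentage points higher from compound 2 to compound 3 (within the scatter) that is expected to remain within the scatter. In this assay compound 3 is therefore estimated at 35%, with a range from 15% to 60%.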

Compound 3, a percentage reported as inhibition, in the whole organism at one dose (the size of the read-out at that dose, not a potency): 66.1%
The estimate for compound 3 lay 31.1 percentage points below the measured number; measured number outside the range, above it.
By their numbers in this assay, from the lowest: compound 2; then compounds 3 and 1 (each within the scatter of the next).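

In this assay, the change from 3-chlorophenyl to 2-methylphenyl goes with a number 33.9 percentage points higher from compound 2 to compound 3 (beyond the scatter), so an aromatic ring on this nitrogen does not in itself go with the low number. The two groups match in heavy atoms and in having one six-membered aromatic ring of carbon only, yet their numbers differ widely, so what counts here is more than the counted features of the group. Replacing methyl with 2-methylphenyl gives a number 3 percentage points lower from compound 1 to compound 3 (within the scatter), so the low number of compound 2 is not shared by every aromatic group at this position, and nothing available here explains the difference.

Compound 2 and compound 3 differ both in the group on the aromatic ring, chlorine or methyl, and in its place on that ring, so these compounds cannot tell which of the two matters. A plain phenyl on the nitrogen would show the level of the ring without either group, and a longer chain such as butyl or a chain ending in an amine would show how much else this position accepts.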